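From 2-cyanobenzyl to 2-chlorobenzyl

The source may report more compounds than this note shows. Statements on the series, on what has been measured and on what is new or still open speak of the compounds shown alone.

Compound 1 `COc1cc(OC)c(-c2coc3cc(OCC=C(C)C)ccc3c2=O)cc1OC` gives 3500 nM
Compound 2 `COc1cc(OC)c(-c2coc3cc(OCc4ccccc4C#N)ccc3c2=O)cc1OC` gives 980 nM

In a functional assay on U-251 cells (Homo sapiens) for antiproliferative activity, read by MTT assay, with a stated time of 24 h (on this read-out lower numbers stand for stronger inhibition and higher numbers for weaker inhibition), compound 2 holds the lower of the two numbers. Compound 3 `COc1cc(OC)c(-c2coc3cc(OCc4ccccc4Cl)ccc3c2=O)cc1OC` remains unmeasured and differs from it by chloro in place of cyano on an aromatic carbon in one place, chloro in place of cyano on an aromatic carbon. Going by the values given here, the single measured step, a 3.6-fold lower number from compound 1 to compound 2 (0.55 log units; beyond the scatter), altered the same side chain, but it exchanged a larger piece and is only a modest guide. Among the compounds with values here, no measured step covers this exchange, so no change beyond the scatter is expected. The expected step is a 1.2-fold higher number from compound 2 to compound 3 (0.09 log units; within the scatter) and no more. Compound 3 is expected at 1200 nM with an estimated range from 400 nM to 3500 nM in this assay when measured.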

Compound 3, half-maximal inhibitory concentration: > 10000 nM
Compound 3 was reported as a limit; the forecaster's own chance of this, stated with the estimate: 2%; at least 8.3-fold (0.92 log units) between middle value and limit.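

Compound 3 sits at a limit of the assay, not at a number: the limit of > 10000 nM in this assay, at which 1 of the 3 values shown sits. In this assay, chloro in place of cyano on an aromatic carbon, ortho to a large group, gives an at least 10-fold higher number from compound 2 to compound 3 (1.00 log units; beyond the scatter), so this position is not indifferent to the exchange. Replacing 2-methylprop-1-en-1-yl with 2-chlorophenyl gives an at least 2.8-fold higher number from compound 1 to compound 3 (0.45 log units; beyond the scatter), so an aromatic ring on this side chain does not by itself give the lower number seen with 2-cyanophenyl.

Going by these compounds, how large either step truly is remains open. So does whether an amine or a carboxylic acid at this position would behave like cyano or like chloro.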